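Removing the phenoxy group from a bromonaphthyridine carboxamide

The compounds below may be only part of what the source reports. "The series", "measured", "known", "first", "only" and "open" are said of these compounds alone.

The series shares the core of compound 1 `N[C@H]1CC[C@H](Nc2c(C(=O)NCc3ccc(Oc4ccccc4)cc3)nc(Br)c3cccnc23)CC1` and is followed in a functional assay on HCT-116 cells (Homo sapiens) for cytotoxicity, read by MTT assay, with a stated time of 72 h; a higher number here means a weaker inhibitor, a lower number a stronger inhibitor. In this assay compound 1 has "not determined" (no result reported). Compound 2 `COC(=O)CNc1c(C(=O)NCc2ccc(F)cc2)nc(Br)c2cccnc12` carries a (methoxycarbonyl)methyl group on the ring nitrogen, and in this assay compound 2 reaches only the limit of > 10000 nM. Compound 3 `C[C@H](Nc1c(C(=O)NCc2ccc(F)cc2)nc(Br)c2cccnc12)c1ccccc1` carries a 1-phenylethyl group there, and in this assay compound 3 likewise reaches only the limit of > 20000 nM. The step that the two limits leave unreadable from compound 2 to compound 3 cannot be read, as both ends are limits, the first described by the limit of > 10000 nM in this assay, at which 1 of the 3 values shown sits, and the second by the limit of > 20000 nM in this assay, at which 1 of the 3 values shown sits.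

Compound 4 `N[C@H]1CC[C@H](Nc2c(C(=O)NCc3ccccc3)nc(Br)c3cccnc23)CC1` differs from compound 1 by hydrogen in place of phenoxy on an aromatic carbon. Going by the values given here, no measured step bears directly on this change; the only two numbers in the set are limits at which no potency was detected. Compound 4 is therefore expected to sit weak as well, with an estimate of 15000 nM in this assay and a range of 3000 nM to 50000 nM, and a limit rather than a number is the likelier outcome.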

Compound 4, half-maximal inhibitory concentration: 7000 nM
Compound 4: the middle estimate sits 2.1-fold (0.33 log units) above what was measured; low and high end bracket the measured number.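

In this assay, going by these compounds alone, compound 4 gives 7000 nM while compound 1 has "not determined" (no result reported) and so no step between the two can be read. Nothing shown here accounts for the value of compound 4. The compounds shown leave open whether hydrogen in place of phenoxy alters the potency of the shared core.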